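Methyl to Ethyl on a Chain Bound to Aromatic Nitrogen

The source may hold more compounds than are shown below. What is called first, only, known or untested is meant among the compounds shown, and "the series" means these compounds.

Compound 1 `O=[N+]([O-])c1cc(CSc2nnc(-c3ccccc3)n2C2CCCCC2)cc([N+](=O)[O-])c1`: in an ADME assay on HepG2 cells (Homo sapiens) for cytotoxicity, with a stated time of 48 h (a higher number here means a weaker inhibitor, a lower number a stronger inhibitor), compound 1 gives > 30000 nM, which is a limit of the assay and not a number.
Compound 2 `O=[N+]([O-])c1cc(CSc2nnc(-c3ccc(Br)cc3)n2Cc2ccccc2)cc([N+](=O)[O-])c1`: in this assay compound 2 gives > 30000 nM, again only a limit.
Compound 3 `Cn1c(SCc2ccccc2)nnc1-c1cc([N+](=O)[O-])cc([N+](=O)[O-])c1`: in this assay compound 3 gives > 30000 nM, also a limit.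

Compound 3 therefore stands nowhere in particular among the numbers shown: every value in this assay is a limit, and the limit of > 30000 nM in this assay, at which 3 of the 3 values shown sit, is the whole of what the three measured compounds tell. Going by the values given here, no two measured compounds differ in a single place, so no measured step exists to lean on.

Compound 4 `CCn1c(SCc2ccccc2)nnc1-c1cc([N+](=O)[O-])cc([N+](=O)[O-])c1` differs from compound 3 by methyl in place of hydrogen on a saturated chain carbon bound to an aromatic nitrogen. Among the compounds with values here, with three limits behind it and no measured step in this assay, one expects the change to move the read-out by nothing beyond the scatter, in no particular direction. The expected step of a number no higher from compound 3 to compound 4 (the limit leaves the size open) is thus one that stays within the scatter. Compound 4 is accordingly expected to give 30000 nM in this assay, with a range from 12000 nM to 75000 nM, and most likely the assay again reports only a limit.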

Compound 4, half-maximal inhibitory concentration: > 30000 nM
Compound 4: a limit, no number; the forecaster's own chance of this, stated with the estimate: 85%; the middle value sits exactly at the limit.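

Compound 3 and compound 4 both give only a limit in this assay, not a number, so no step can be read between them: the limit of > 30000 nM in this assay, at which 4 of the 4 values shown sit.

The compounds shown leave open where any of their true values lies, and whether methyl to ethyl changes the read-out at all.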